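The source may report more compounds than this note shows. Statements on the series, on what has been measured and on what is new or still open speak of the compounds shown alone.

In a functional assay on A2780/DX3 cells (Homo sapiens) for antiproliferative activity, read by MTT assay, with a stated time of 3 days (a lower number here means a stronger inhibitor, a higher number a weaker inhibitor), compound 2 (`CC1=CSC(O)(c2cccc([N+](=O)[O-])c2)c2noc(=O)n21`) gives 129000 nM. Compound 3 (`CC/C=C\COC1(c2ccc(Cl)cc2)SC=C(C)n2c1noc2=O`) gives 103000 nM in this assay, and that number lies within the scatter of the value of compound 2, so the two cannot be told apart. Compound 1 (`CCCCCCCCCCCCCCCCCCOC1(c2ccc(Br)cc2)SC=C(C)n2c1noc2=O`) reached only the limit of > 100000 nM in this assay, as the limit of > 100000 nM in this assay, at which 1 of the 3 values shown sits, records. Compound 2 thus stands among a set of weak inhibitors, with only two actual numbers shown and neither set apart from the other.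

Compound 4 (`CC1=CSC(O)(c2cccc(Cl)c2)c2noc(=O)n21`) has not yet been measured. It differs from compound 2 by chloro in place of nitro on an aromatic carbon. No measured pair of this kind exists among the compounds shown, so the change is expected to bring no step beyond the scatter in this assay, in either direction. Compound 4 is therefore estimated at 120000 nM, with a range from 40000 nM to 350000 nM, which means an expected step of a 1.1-fold lower number from compound 2 to compound 4 (0.03 log units; within the scatter).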

Compound 4, half-maximal inhibitory concentration: > 100000 nM
Compound 4 was reported as a limit (the forecaster's own chance of this, stated with the estimate: 40%); the middle value is on the limit's open side.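

In this assay compound 4 gives > 100000 nM, which is a limit and not a number. The step from compound 2 to compound 4 cannot be read. The compounds shown leave open whether chloro in place of nitro on an aromatic carbon moves the number in this assay at all.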